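This account rests on a few compounds, and the source may have more. Where it says the series, first, only, none or still open, it means among the compounds named here.

Of the compounds shown here, three of a shared core have been measured in an assay for inhibition of CDK8/Cyclin C (Homo sapiens), read by fluorescence polarization; a lower number here means a stronger inhibitor, a higher number a weaker inhibitor. Compound 1 `Clc1ccc(Oc2cncc3sc(-c4nn[nH]n4)cc23)cc1` gives 1.1 nM. Compound 2 `O=C(O)c1cc2c(Oc3ccc(Cl)cc3)cncc2s1` gives 2.8 nM, and the step of a 2.5-fold higher number from compound 1 to compound 2 (0.41 log units; beyond the scatter) shows what exchanging one group on the core does. Compound 3 `COc1ccc(Oc2cncc3sc(C(N)=O)cc23)cc1` gives 25 nM, the highest of the three numbers and therefore the weakest inhibitor among them; its nearest neighbour is compound 2, and its furthest compound 1.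

Compound 4 `N#Cc1ccc(Oc2cncc3sc(C(N)=O)cc23)cc1` differs from compound 3 in a single place: cyano in place of methoxy on an aromatic carbon. Among the measured compounds shown here, no measured pair shows this exchange; the only step in hand, from compound 1 to compound 2, concerns a different position and a different pair of groups, so it cannot tell how swapping methoxy for cyano will turn out. Going by these compounds, both groups that leave and enter are small and carry one hydrogen-bond acceptor each, so the change is a small one on paper, but its effect on the number is unknown from these data. Compound 4 is therefore expected to stay close to compound 3, with no change at the digits printed from compound 3 to compound 4 (within the scatter) as the expected step. The estimate for compound 4 is 25 nM, with a range from 8 nM to 75 nM.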

Compound 4, half-maximal inhibitory concentration: 5.1 nM
Beside the measured number, compound 4's estimate is 4.9-fold (0.69 log units) above it; the whole stated range lies above it.
By their numbers in this assay, from the lowest: compound 1; then compounds 2 and 4 (each within the scatter of the next); then compound 3.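

Among the compounds shown here, this is the first exchange seen at this place, on an aromatic carbon of the six-membered ring of carbon only, para to a large group, and in this assay it gives a 4.9-fold lower number from compound 3 to compound 4 (0.69 log units; beyond the scatter) with cyano in place of methoxy. The number therefore responds to this position, even though the two groups match in heavy atoms, hydrogen-bond donors, hydrogen-bond acceptors and net charge, so those counts alone do not predict the step; what sets cyano apart in the count is its triple bond. Nothing measured here gives a reason for the step.

The compounds shown leave open how other groups would read at this same place, such as an amine, a fluorine atom or a longer chain like ethoxy, and so whether the step reflects something particular to cyano or is shared by other groups. They also leave open whether the exchange would act the same way with the 2H-tetrazol-5-yl or carboxy group on the core, since compound 1 and compound 2 differ from compound 4 in more than one place.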